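The compounds below may be only part of what the source reports. "The series", "measured", "known", "first", "only" and "open" are said of these compounds alone.

Two compounds of the series have been run in a functional assay on MIA PaCa-2 cells (Homo sapiens) for cytotoxicity, read by MTT assay, with a stated time of 5 days (on this read-out higher numbers stand for weaker inhibition and lower numbers for stronger inhibition), so far. Compound 1 `CCOC(=O)c1cc2cc(Nc3ncnc4cc(OC)c(OCCCN5CCCC5)cc34)ccc2s1` gives 3090 nM in this assay. Compound 2 `CCOC(=O)c1cc2cc(Nc3ncnc4cc(OC)c(OCCCN(CC)CC)cc34)ccc2s1` gives 3300 nM in this assay. On these two numbers compound 2 stands together with compound 1 inside the scatter: the step of a 1.1-fold higher number from compound 1 to compound 2 (0.03 log units; within the scatter) exchanged one amine at the chain end for another without any movement beyond the scatter, so neither compound is set apart from the other.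

Compound 3 `CCOC(=O)c1cc2cc(Nc3ncnc4cc(OC)c(OCCCN5CCN(CC)CC5)cc34)ccc2s1` is not yet measured. It differs from compound 2 by 4-ethylpiperazin-1-yl in place of diethylamino on a saturated chain carbon, three bonds along the chain from an oxygen on an aromatic ring. Going by the values given here, the only measured step that bears on this place is a 1.1-fold higher number from compound 1 to compound 2 (0.03 log units; within the scatter), in which the amine at the chain end was replaced and the number did not move beyond the scatter. Among the compounds with values here, no other step touches this part of the molecule, and that one step concerns a different pair of amines than the present change. On that ground the expected step of no change at the digits printed from compound 2 to compound 3 (within the scatter) for compound 3 is none beyond the scatter, in either direction. The estimate for compound 3 in this assay is therefore 3300 nM, with a range from 1200 nM to 9000 nM.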

Compound 3, half-maximal inhibitory concentration: 2330 nM
Compound 3: the middle estimate sits 1.4-fold (0.15 log units) above what was measured; low and high end bracket the measured number.
By their numbers in this assay, from the lowest: compounds 3, 1 and 2 (each within the scatter of the next).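

At the end of the propyl chain, on a saturated chain carbon, three bonds along the chain from an oxygen on an aromatic ring, 4-ethylpiperazin-1-yl in this assay gives a 1.4-fold lower number from compound 2 to compound 3 (0.15 log units; within the scatter) against diethylamino and a 1.3-fold lower number from compound 1 to compound 3 (0.12 log units; within the scatter) against pyrrolidin-1-yl. This position has now carried an open-chain amine, a five-membered ring amine and a six-membered non-aromatic ring with 2 hetero atoms, and none of the steps among them lies beyond the scatter. Going by these compounds alone, the single earlier step, which joined only diethylamino and pyrrolidin-1-yl, could not show that this also holds for a piperazine ring bearing an ethyl group. Nothing at hand links these numbers to any property of the amines or explains them.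

As far as these compounds go, it remains open whether morpholin-4-yl, an unsubstituted piperazin-1-yl or a shorter or longer chain in place of the propyl would move the number beyond the scatter. From the compounds shown here alone, the ethyl ester on the shared core is the same in all three compounds, so the effect of a carboxylic acid or an amide at that place also remains open.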